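The source may hold more compounds than are shown below. What is called first, only, known or untested is meant among the compounds shown, and "the series" means these compounds.

Compound 1 `CC1CC/C(=N\Nc2ccc(F)cc2)c2ncc(C(=O)O)c(=O)n21`: a limit of the assay, not a number, > 1000 umol/kg.
Compound 2 `CC1CC/C(=N\Nc2ccccc2Br)c2ncc(C(=O)O)c(=O)n21`: again a limit, > 320 umol/kg.
Compound 3 `CC1CC/C(=N\Nc2cccc(I)c2)c2ncc(C(=O)O)c(=O)n21`: 1000 umol/kg.

All three were tested in a functional assay on the whole organism for inhibition, with Rattus norvegicus as the target; on this read-out lower numbers stand for an effect already at smaller amounts and higher numbers for an effect only at larger amounts of compound. Compound 3 is the only one of them with an actual number; the results for the other two are limits, meaning no effect was seen up to the highest amount given. The steps between them tell little. The step that the two limits leave unreadable from compound 1 to compound 2 cannot be read, the step that the limit leaves unreadable from compound 2 to compound 3 cannot be read either, and a number no higher from compound 1 to compound 3 (the limit leaves the size open) only says which side it lies on, not how far.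

Compound 4 `CC1CC/C(=N\Nc2ccc(O)cc2)c2ncc(C(=O)O)c(=O)n21` has not yet been measured. It differs from compound 3 in a single place: 4-hydroxyphenyl in place of 3-iodophenyl on an amine nitrogen. Within the data shown here, no measured compound carries a 4-hydroxyphenyl, and none of the measured steps has a readable size, so there is nothing here that can say whether swapping the 3-iodophenyl for it should help, hurt, or leave things unchanged.

In this assay the step is therefore expected to be no change at the digits printed from compound 3 to compound 4 (within the scatter), with no direction favoured and a wide spread. On that basis compound 4 is estimated at 1000 umol/kg, somewhere between 300 umol/kg and 3000 umol/kg.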

Compound 4, dose for 50% inhibition: > 100 umol/kg
Compound 4: only a limit was reported; the forecaster's own chance of this, stated with the estimate: 50%; the middle value does not contradict the limit.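

The result for compound 4 is a limit, > 100 umol/kg, and not a number. Its steps from compound 1, compound 2 and compound 3 therefore cannot be read. The compounds shown leave open whether the 4-hydroxyphenyl of compound 4 gives an effect at smaller, similar or larger amounts than the 3-iodophenyl of compound 3.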